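The compounds below may be only part of what the source reports. "The series", "measured", "known", "first", "only" and "open" are said of these compounds alone.

Compound 2 `O=C(Nc1ccc(Oc2ccnc3[nH]ccc23)cc1)c1cc2cccnc2n(-c2ccc(Br)cc2)c1=O` gives 280 nM in a functional assay on A549 cells (Homo sapiens) for antiproliferative activity, read by MTT assay, with a stated time of 72 h (on this read-out lower numbers stand for stronger inhibition and higher numbers for weaker inhibition), the lowest of the three numbers in hand. Compound 1 `O=C(Nc1ccc(Oc2ccnc3[nH]ccc23)cc1)c1cc2cccnc2n(-c2ccc(Cl)cc2)c1=O` gives 290 nM in this assay, and the step of a 1.0-fold lower number from compound 1 to compound 2 (0.02 log units; within the scatter) lies within the scatter, so the two are not ordered. Compound 3 `O=C(Nc1ccc(Oc2ccnc3[nH]ccc23)cc1)c1cc2cccnc2n(-c2ccc(Br)cc2F)c1=O` gives 1570 nM in this assay, with the steps of a 5.4-fold higher number from compound 1 to compound 3 (0.73 log units; beyond the scatter) and a 5.6-fold higher number from compound 2 to compound 3 (0.75 log units; beyond the scatter) both beyond the scatter.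

Compound 4 `O=C(Nc1ccc(Oc2ccnc3[nH]ccc23)c(F)c1)c1cc2cccnc2n(-c2ccc(Br)cc2)c1=O` differs from compound 2 by fluoro in place of hydrogen on an aromatic carbon. Going by the values given here, the entering group sits on a different aromatic ring from the one changed in compound 3, so no measured step tests this exact position. Among the compounds with values here, the only step of the same kind is the one from compound 2 to compound 3, a fluoro for hydrogen change on the other ring, which cost a 5.6-fold higher number from compound 2 to compound 3 (0.75 log units; beyond the scatter). That gives a weak prior that a fluoro added to this series raises the number, but its transfer to a different ring is uncertain. A modest rise, smaller than that step and with a wide range, is therefore expected. Compound 4 is estimated to give about 450 nM in this assay, between 150 nM and 1400 nM. The expected step is a 1.6-fold higher number from compound 2 to compound 4 (0.21 log units; within the scatter).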

Compound 4, half-maximal inhibitory concentration: 210 nM
Beside the measured number, compound 4's estimate is 2.1-fold (0.33 log units) above it, within the range that was stated.
By their numbers in this assay, from the lowest: compounds 4, 2 and 1 (each within the scatter of the next); then compound 3.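

The step of a 1.3-fold lower number from compound 2 to compound 4 (0.12 log units; within the scatter) in this assay shows that fluoro in place of hydrogen is tolerated on this six-membered aromatic ring of carbon only, ortho to a large group and meta to a large group. The same kind of exchange on the other aromatic ring gave a 5.6-fold higher number from compound 2 to compound 3 (0.75 log units; beyond the scatter), so among these compounds the outcome of adding fluoro depends on which ring carries it. Nothing available here accounts for that difference.

Compound 4 is the only compound shown with a change on this ring, so a single small substituent is all that has been seen there. Going by these compounds, whether the position also accepts a chloro, a methoxy or an amine remains open, as does whether the tolerance of fluoro carries over to the parent bearing 4-chlorophenyl.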